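The compounds below may be only part of what the source reports. "The series", "measured", "known", "first", "only" and "open" are said of these compounds alone.

Measured so far in a functional assay on MOLT-4 cells (Homo sapiens) for antiproliferative activity, read by CCK-8 assay, with a stated time of 72 h; a lower number here means a stronger inhibitor, a higher number a weaker inhibitor
- compound 1 `Cc1cc(Nc2cc(N3CCN(C)CC3)nc(Nc3ccc(Cl)cc3)n2)n[nH]1` gives 53.1 nM
- compound 2 `COc1cccc(Nc2nc(Nc3cc(C)[nH]n3)cc(N3CCN(C)CC3)n2)c1` gives 192 nM
- compound 3 `Cc1cc(Nc2cc(N3CCN(C)CC3)nc(Nc3ccc(C#N)cc3)n2)n[nH]1` gives 13.6 nM

Compound 2 has the highest number of the three and is the weakest of this small set. The gap on one side is modest (a 3.6-fold higher number from compound 1 to compound 2 (0.56 log units; beyond the scatter)) and the gap on the other is large (a 14-fold lower number from compound 2 to compound 3 (1.15 log units; beyond the scatter)).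

Compound 4 `COc1ccc(Nc2nc(Nc3cc(C)[nH]n3)cc(N3CCN(C)CC3)n2)cc1` has not yet been measured. Its change is 4-methoxyphenyl in place of 3-methoxyphenyl on a nitrogen on an aromatic ring. Within the data shown here, no measured pair keeps one group fixed and changes only where it sits, so no step tests this change directly. The closest evidence is indirect. Set against compound 2 (192 nM), the 4-chlorophenyl compound 1 (53.1 nM) and the 4-cyanophenyl compound 3 (13.6 nM) are both stronger inhibitors, but those steps also change the group itself. The step between the two (a 3.9-fold lower number from compound 1 to compound 3 (0.59 log units; beyond the scatter)) shows that the group alone can move the number by a modest amount. Among the measured compounds shown here, with only two compounds behind this reading, a modest step toward a lower number is expected in this assay (a 2.3-fold lower number from compound 2 to compound 4 (0.35 log units; beyond the scatter)). Compound 4 is estimated at 85 nM (expected range 28 nM to 250 nM).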

Compound 4, half-maximal inhibitory concentration: 116 nM
Beside the measured number, compound 4's estimate is 1.4-fold (0.14 log units) below it; low and high end bracket the measured number.
By their numbers in this assay, from the lowest: compound 3; then compound 1; then compounds 4 and 2 (each within the scatter of the next).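

In this assay, among these compounds, the change from 3-methoxyphenyl to 4-methoxyphenyl on a nitrogen on an aromatic ring gives the first direct reading of where the methoxy sits, and the step stays within the scatter (a 1.7-fold lower number from compound 2 to compound 4 (0.22 log units; within the scatter)), so this shift in place has no resolved effect on the number here. The group itself does separate the compounds: methoxy in place of cyano gives the wider step (an 8.5-fold higher number from compound 3 to compound 4 (0.93 log units; beyond the scatter)), and methoxy in place of chloro a smaller one that is still beyond the scatter (a 2.2-fold higher number from compound 1 to compound 4 (0.34 log units; beyond the scatter)), which orders these three as cyano, then chloro, then methoxy from the lowest number. No measurement at hand gives a reason for either the flat change of place or the spread among the groups.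

Only methoxy is shown in two places, so it remains open whether the place of chloro or cyano matters as little as that of methoxy. Going by these compounds, it also remains open how an amine, a carboxylic acid or an amide on this phenyl ring would compare with compound 3 at 13.6 nM in this series.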